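Swapping a thiophene for a methyl isothiazole

The source may hold more compounds than are shown below. What is called first, only, known or untested is meant among the compounds shown, and "the series" means these compounds.

Compound 1 `c1ccc(-c2ccns2)c(OCC2=NCCN2)c1` gives 25.1 nM in a functional assay for activation of Alpha-1D adrenergic receptor (Homo sapiens), read by calcium flux; on this read-out lower numbers stand for an effect already at smaller amounts and higher numbers for an effect only at larger amounts of compound. Compound 2 `Cc1ccc(-c2ccccc2OCC2=NCCN2)s1` reaches only < 100000 nM in this assay, which is a limit of the assay, not a number. The step that the limit leaves unreadable from compound 1 to compound 2 therefore cannot be sized because the limit of < 100000 nM in this assay, at which 1 of the 2 values shown sits, covers one of its two ends. Compound 3 `Cc1cnsc1-c1ccccc1OCC1=NCCN1` carries 4-methyl-1,2-thiazol-5-yl in place of 5-methylthiophen-2-yl on an aromatic carbon. Within the data shown here, no measured step shows this exact change, and the single step touching compound 2 is unreadable. Compound 3 is expected to give about 100 nM in this assay, estimated within 15 nM to 1000 nM. The step that the limit leaves unreadable from compound 2 to compound 3 is accordingly expected to be a large gain.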

Compound 3, half-maximal effective concentration: < 100000 nM
Compound 3: only a limit was reported (the forecaster's own chance of this, stated with the estimate: 10%); the middle value lies beyond the limit too.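

The steps to compound 3 from compound 1 and from compound 2 cannot be read, since each rests on a limit: the limit of < 100000 nM in this assay, at which 2 of the 3 values shown sit.

On these data alone, how much the added methyl changes compound 3 relative to compound 1, and whether compound 2 and compound 3 differ at all in this assay, stays open.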